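Swapping one benzothiazole group for another in compound 4

A few compounds are considered here, and "the series" means these few. Any claim that something is new, unique, unknown or untested is made for them only; others in the source may bear on it.

Measured in a functional assay (blood) for inhibition, with Homo sapiens as the target; a lower number here means a stronger inhibitor, a higher number a weaker inhibitor:
Compound 1 `CC(C)(C)Sc1c(CC(C)(C)C(=O)O)n(Cc2ccc(Cl)cc2)c2ccc(OCc3ccc4cc(F)ccc4n3)cc12`: 880 nM
Compound 2 `CC(C)(C)Sc1c(CC(C)(C)C(=O)O)n(Cc2ccc(Cl)cc2)c2ccc(OCc3cc4ccccc4cn3)cc12`: > 3000 nM, which is a limit of the assay and not a number
Compound 3 `COc1ccc2nc(COc3ccc4c(c3)c(SC(C)(C)C)c(CC(C)(C)C(=O)O)n4Cc3ccc(Cl)cc3)sc2c1`: 670 nM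

Compound 3, at 670 nM, lies within the scatter of compound 1 and is clearly separated from compound 2, with an at least 4.4-fold lower number from compound 2 to compound 3 (0.65 log units; beyond the scatter). The unmeasured compound 4 `Cc1nc2ccc(COc3ccc4c(c3)c(SC(C)(C)C)c(CC(C)(C)C(=O)O)n4Cc3ccc(Cl)cc3)cc2s1` differs from compound 3 in one place only, on a saturated chain carbon bound to an oxygen on an aromatic ring. There, 2-methyl-1,3-benzothiazol-6-yl stands in place of 6-methoxy-1,3-benzothiazol-2-yl (2-methyl-1,3-benzothiazol-6-yl in place of 6-methoxy-1,3-benzothiazol-2-yl on a saturated chain carbon bound to an oxygen on an aromatic ring).

Among the measured compounds shown here, all the measured steps come from this same place, and they do not agree. One exchange of groups, a 1.3-fold lower number from compound 1 to compound 3 (0.12 log units; within the scatter), stays within the scatter, while another, an at least 3.4-fold higher number from compound 1 to compound 2 (0.53 log units; beyond the scatter), goes beyond it towards a weaker inhibitor. For the measured compounds named here, no measured compound carries the entering group, so these steps are only a rough guide. Weighing the two, a modest rise in the number is expected in this assay, with an estimated change of a 2.1-fold higher number from compound 3 to compound 4 (0.32 log units; beyond the scatter). For compound 4 the estimated value is 1400 nM, with an expected range from 500 nM to 3500 nM.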

Compound 4, half-maximal inhibitory concentration: > 3000 nM
Compound 4 was reported as a limit (the forecaster's own chance of this, stated with the estimate: 20%); middle value at least 2.1-fold (0.33 log units) from the limit.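

In this assay compound 4 gives > 3000 nM, which is a limit of the assay and not a number. The earlier compounds shown here left open whether a benzothiazole at this place would in general hold the activity, and this change shows that it does not: the two benzothiazole groups have the same kinds of ring, yet the result is an at least 4.4-fold higher number from compound 3 to compound 4 (0.65 log units; beyond the scatter) and an at least 3.4-fold higher number from compound 1 to compound 4 (0.53 log units; beyond the scatter), so the outcome depends on which benzothiazole group sits on the saturated chain carbon bound to an oxygen on an aromatic ring. The step between compound 2 and compound 4 cannot be read, and the two cannot be put in order, because both values are limits: the limit of > 3000 nM in this assay, at which 2 of the 4 values shown sit.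

The two benzothiazole groups differ both in what they carry, methoxy or methyl, and in how they are joined to the chain, and no compound shown changes one of these alone, so the source of the loss stays open. Also open, on these data alone, is how a benzothiazole carrying an amine or a carboxylic acid in place of the methoxy or methyl group would behave here.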